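Diethylamino ethers: one more chain carbon

This account rests on a few compounds, and the source may have more. Where it says the series, first, only, none or still open, it means among the compounds named here.

In a functional assay on PC-3 cells (Homo sapiens) for antiproliferative activity, read by WST assay, with a stated time of 3 days (on this read-out lower numbers stand for stronger inhibition and higher numbers for weaker inhibition), compound 1 (`CCCCCCOc1c(-c2cc(OC)c(OC)c(OC)c2)oc2ccccc2c1=O`) gives 29200 nM and compound 2 (`CCN(CC)CCCOc1c(-c2cc(OC)c(OC)c(OC)c2)oc2ccccc2c1=O`) gives 13600 nM while compound 3 (`CCN(CC)CCCCOc1c(-c2cc(OC)c(OC)c(OC)c2)oc2ccccc2c1=O`) gives 13700 nM and so sits level with compound 2 within the scatter and under compound 1. Compound 4 (`CCN(CC)CCCCCOc1c(-c2cc(OC)c(OC)c(OC)c2)oc2ccccc2c1=O`) remains unmeasured. Its difference from compound 3 is (diethylamino)methyl in place of diethylamino on a saturated chain carbon, four bonds along the chain from an oxygen on an aromatic ring and reads in words as (diethylamino)methyl in place of diethylamino on a saturated chain carbon, four bonds along the chain from an oxygen on an aromatic ring.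

For the measured compounds named here, the nearest precedent is the same change three bonds along the chain, which gave a 1.0-fold higher number from compound 2 to compound 3 (0.00 log units; within the scatter) and so no real shift. The modest steps of a 2.1-fold lower number from compound 1 to compound 2 (0.33 log units; beyond the scatter) and a 2.1-fold lower number from compound 1 to compound 3 (0.33 log units; beyond the scatter) only separate compound 1 from the two diethylamino compounds and say little about chain length. Accordingly the expected step in this assay is a 1.1-fold lower number from compound 3 to compound 4 (0.02 log units; within the scatter) and no shift beyond the scatter is foreseen. For compound 4 the estimated value is 13000 nM with an expected range from 7000 nM to 24000 nM in this series.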

Compound 4, half-maximal inhibitory concentration: 6600 nM
Beside the measured number, compound 4's estimate is 2.0-fold (0.29 log units) above it; measured number outside the range, below it.
By their numbers in this assay, from the lowest: compound 4; then compounds 2 and 3 (each within the scatter of the next); then compound 1.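

In this assay, lengthening the chain at this position is not always silent: a 2.1-fold lower number from compound 3 to compound 4 (0.32 log units; beyond the scatter), whereas the same change three bonds along the chain gave no shift beyond the scatter. The longer chain also separates compound 4 from the shorter diethylamino ether, with a 2.1-fold lower number from compound 2 to compound 4 (0.31 log units; beyond the scatter), so chain length does matter within the diethylamino ethers, though only the last extension shows it. Against the hexyl ether, the gap widens to a 4.4-fold lower number from compound 1 to compound 4 (0.65 log units; beyond the scatter), which is the largest step in this set and leaves compound 4 beyond the scatter of all three others.

Going by these compounds, whether a longer chain than that of compound 4 lowers the number further, and whether a piperidine or dimethylamino group in place of diethylamino keeps the step, stays open. Nothing available bears on what lies behind the step.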